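Side-chain swap on the shared core: compound 1 to compound 4

The source may report more compounds than this note shows. Statements on the series, on what has been measured and on what is new or still open speak of the compounds shown alone.

Three measured compounds share one core. Compound 1 `CC1=C(N2CC2)C(=O)C(CCC(=O)N(C)C)=C(N2CC2)C1=O` carries a 2-(dimethylcarbamoyl)ethyl chain; in a functional assay on L1210 cells (Mus musculus), with a stated time of 1 days (a higher number here means a more potent compound, by a factor of ten per unit of this negative logarithm, a lower number a less potent compound), compound 1 gives 4.84. Compound 2 `CCC1=C(N2CC2)C(=O)C(CC)=C(N2CC2)C1=O` gives 4.79 in this assay, and compound 3 `COCCOC(COC(N)=O)C1=C(N2CC2)C(=O)C(C)=C(N2CC2)C1=O` gives 4.96 in this assay. Compound 1 stands second highest of the three numbers, with compound 2 nearest and compound 3 furthest; both gaps lie within the usual scatter, so the three values are best read as one level.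

The unmeasured compound 4 `COCCC1=C(N2CC2)C(=O)C(C)=C(N2CC2)C1=O` differs from compound 1 in one place: methoxy in place of dimethylcarbamoyl on a saturated chain carbon, two bonds along the chain from a double-bonded ring carbon. For the measured compounds named here, no pair of measured compounds isolates this change, so there is no measured step to lean on. What is known is that the three measured side chains, of different length and make-up, all return values within the scatter of each other. On that basis only a small step is expected, in either direction and not beyond the scatter: a number 0.06 log units higher from compound 1 to compound 4 (within the scatter). Compound 4 is therefore estimated at 4.9 in this assay, with a range from 4.4 to 5.4 that allows for the absence of any direct comparison.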

Compound 4, logarithm of the reciprocal of the active concentration, log(1/C): 5.12
Estimate against measurement, compound 4: 0.22 log units below; low and high end bracket the measured number.
By their numbers in this assay, from the lowest: compounds 2, 1, 3 and 4 (each within the scatter of the next, the first and the last beyond it).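

For the compounds shown here, the step of a number 0.28 log units higher from compound 1 to compound 4 (within the scatter) in this assay is the first one that isolates a single change, methoxy in place of dimethylcarbamoyl on a saturated chain carbon, two bonds along the chain from a double-bonded ring carbon. It lies within the scatter, so at this position the 2-(dimethylcarbamoyl)ethyl chain can give way to 2-methoxyethyl with no readable change in this read-out, and the amide is not needed to hold the level seen here. Both groups count one hydrogen-bond acceptor and no donor, so this pair does not test whether an acceptor on the chain matters at all. Nothing available explains why the two chains read alike.

The compounds shown leave open whether any oxygen or nitrogen is needed on this chain, which a plain propyl chain in the same place would address. They also leave open how far the position stays this forgiving once the chain carries a charged group such as an amine or a carboxylic acid, or grows into a longer chain.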